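From methoxycarbonyl to isobutoxycarbonyl on a shared core

The compounds below may be only part of what the source reports. "The series", "measured", "known", "first", "only" and "open" are said of these compounds alone.

Within the data shown here, only two numbers exist so far. In an assay on membranes from HeLa cells for displacement of a labelled ligand from adenosine receptor A3 (Homo sapiens), read by scintillation counting, with a stated time of 180 min, tested at 1 uM (on this read-out lower numbers stand for less inhibition and higher numbers for more inhibition at the one concentration tested (going by the name of the read-out)), compound 2 `COC(=O)C1=C(C)N(C)C(=O)NC1c1cccs1` gives 15%, while compound 1 `COC(=O)C1=C(C)N(C)C(=O)NC1c1ccoc1` gives 7%; the step of a number 8 percentage points higher from compound 1 to compound 2 (within the scatter) is within the scatter, so the two cannot be told apart. Compound 3 `CC1=C(C(=O)OCC(C)C)C(c2cccs2)NC(=O)N1C` differs from compound 2 by isopropyl in place of hydrogen on a saturated chain carbon bound to an oxygen next to a carbonyl group. Among the measured compounds shown here, no measured step touches this part of the structure; the one step measured swapped a ring on a saturated ring carbon and stayed within the scatter. A step of no change at the digits printed from compound 2 to compound 3 (within the scatter) is therefore expected, with no direction favoured beyond the scatter. Compound 3 is estimated at 15%, between 0% and 35%.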

Compound 3, a percentage reported as inhibition, at one concentration (the size of the read-out at that concentration, not a potency): 5%
Compound 3: middle estimate off by 10 percentage points, on the high side, within the range that was stated.
By their numbers in this assay, from the lowest: compounds 3, 1 and 2 (each within the scatter of the next).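

Going from methoxycarbonyl to isobutoxycarbonyl, the first measured change at this position, gives a number 10 percentage points lower from compound 2 to compound 3 (within the scatter) in this assay. Adding isopropyl on this saturated chain carbon therefore gives a result that cannot be told apart from that of compound 2. Nothing available offers a reason for this result.

A carboxylic acid at this position, or an ester with a longer chain such as octyl, remains an open case. A reading at one concentration also leaves the potency of these compounds unknown.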